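A few compounds are considered here, and "the series" means these few. Any claim that something is new, unique, unknown or untested is made for them only; others in the source may bear on it.

Three compounds share one core and differ only in the aromatic part that carries the sulfonyl group. Compound 2 `COc1ccccc1-c1ccc(S(=O)(=O)N2CCC(N3CCC(C)CC3)CC2)cc1` is the one whose aromatic part bears a 2-methoxyphenyl group; in a functional assay on DLD-1 cells (Homo sapiens) for antiproliferative activity, read by CellTiter-Glo, with a stated time of 72 h (on this read-out lower numbers stand for stronger inhibition and higher numbers for weaker inhibition), compound 2 gives 26 nM. Compound 3 `CC(=O)Nc1ccc(S(=O)(=O)N2CCC(N3CCC(C)CC3)CC2)c2ccccc12` gives 1100 nM in this assay. For compound 1 `CC1CCN(C2CCN(S(=O)(=O)c3cccnc3Cl)CC2)CC1` only a limit is known in this assay, as compound 1 sits at > 5000 nM, described in the limit of > 5000 nM in this assay, at which 1 of the 3 values shown sits. Of the two real numbers, compound 2 has the lower one, and compound 3 stands a long way behind it, beyond the scatter of repeated measurements.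

Compound 4 `CCCCOc1ccc(S(=O)(=O)N2CCC(N3CCC(C)CC3)CC2)cc1` has not yet been measured. It differs from compound 2 in one place: butoxy in place of 2-methoxyphenyl on an aromatic carbon. The second aromatic ring is lost, and the remaining group is a chain of four carbons and one oxygen.

Among the measured compounds shown here, no measured pair here shows what such a change does, so the expectation rests on compound 2 alone. A weakening step is expected, the estimated step from compound 2 to compound 4 in this assay being a 9.6-fold higher number from compound 2 to compound 4 (0.98 log units; beyond the scatter). For compound 4 the estimate in this assay is 250 nM, with a likely range from 50 nM to 1500 nM.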

Compound 4, half-maximal inhibitory concentration: 2300 nM
For compound 4 the middle estimate is 9.2-fold (0.96 log units) below the measured one; the whole stated range lies below it.
By their numbers in this assay, from the lowest: compound 2; then compound 3; then compound 4. At a limit, above all of these: compound 1.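

Among the compounds shown here, the earlier compounds differ in more than one place, so this is the first direct reading of a single change at this position, para to a large group. In this assay, putting butoxy in place of 2-methoxyphenyl gives an 88-fold higher number from compound 2 to compound 4 (1.95 log units; beyond the scatter), a large step even though both groups carry one hydrogen-bond acceptor, so keeping an oxygen on the group does not by itself keep the low number. Nothing measured here explains why the step is so large.

The change both removes an aromatic ring and alters the size of the group, and these two effects cannot be told apart from compounds 2 and 4 alone. From the compounds shown here alone, a plain phenyl group and a longer chain such as octyloxy at the same position could separate them, and the effect of an amine there also remains open.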